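The source may report more compounds than this note shows. Statements on the series, on what has been measured and on what is new or still open speak of the compounds shown alone.

Compound 1, `Cc1ccc(NC(=O)c2cccc(/C=C3\CC(=O)N(c4ccccc4)C3=O)c2)cc1C`, was tested in an ADME assay on NCM460 cells (Homo sapiens) for cytotoxicity, read by MTT assay, with a stated time of 72 h; a higher number here means a weaker inhibitor, a lower number a stronger inhibitor. In this assay compound 1 gives > 100000 nM, which is a limit of the assay rather than a number. A second compound, compound 2, `CCCCNC(=O)c1cccc(/C=C2\CC(=O)N(Cc3ccccc3)C2=O)c1`, was also examined. In this assay compound 2 gives > 100000 nM, again a limit and not a number. Both readings sit at the same point: the limit of > 100000 nM in this assay, at which 2 of the 2 values shown sit. So compound 1 stands exactly where every measured value shown stands, and no number separates it from compound 2.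

Compound 3, `O=C(Nc1ccc(F)cc1)c1cccc(/C=C2\CC(=O)N(c3ccccc3)C2=O)c1`, has not yet been measured. It differs from compound 1 in one place: 4-fluorophenyl in place of 3,4-dimethylphenyl on an amide-type nitrogen. With both measured compounds resting at a limit, no step beyond the scatter is expected from compound 1 to compound 3, and the estimated step that the limit leaves unreadable from compound 1 to compound 3 reflects that. Compound 3 is expected to give about 150000 nM, most likely reported again as a limit, with a range from 60000 nM to 400000 nM.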

Compound 3, half-maximal inhibitory concentration: > 100000 nM
Compound 3: a limit, no number; the forecaster's own chance of this, stated with the estimate: 85%; the middle value is on the limit's open side.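

No step can be read from compound 1 to compound 3, because both rest at the same limit and neither gives a number: the limit of > 100000 nM in this assay, at which 3 of the 3 values shown sit.

The compounds shown leave open whether any change to the shared core or its groups would give a measurable number in this assay at all.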